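Phenyl for methyl on the piperazine of compound 1

The source may report more compounds than this note shows. Statements on the series, on what has been measured and on what is new or still open speak of the compounds shown alone.

Compound 1 `CN1CCN(C(=O)c2c(NC(=O)NS(=O)(=O)c3ccccc3)sc3c2CCCCC3)CC1` carries a 4-methylpiperazin-1-yl group on the carbonyl carbon of the shared core. In a functional assay on NSCLC cells (Homo sapiens) for inhibition, with a stated time of 48 h (on this read-out lower numbers stand for stronger inhibition of growth and higher numbers for weaker inhibition of growth), compound 1 gives 22300 nM, the highest of the two numbers measured in this assay. Its nearest neighbour is compound 2 `O=C(Nc1sc2c(c1C(=O)NNc1ccc(Cl)cc1)CCCCC2)NS(=O)(=O)c1ccccc1`, which in this assay gives 8600 nM; the step of a 2.6-fold lower number from compound 1 to compound 2 (0.41 log units; beyond the scatter) replaces the whole 4-methylpiperazin-1-yl group with a ((4-chlorophenyl)amino)amino group, so it alters the same carbonyl position but not in the way examined here.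

Compound 3 `O=C(Nc1sc2c(c1C(=O)N1CCN(c3ccccc3)CC1)CCCCC2)NS(=O)(=O)c1ccccc1` differs from compound 1 by phenyl in place of methyl on an amine nitrogen in a ring, read one bond further out as 4-methylpiperazin-1-yl to 4-phenylpiperazin-1-yl. Among the compounds with values here, no measured step changes a substituent on that ring nitrogen, so the only guidance is that the one change made at the carbonyl position, compound 1 to compound 2, lowered the number modestly. A modest lowering is therefore expected for compound 3 as well, with wide uncertainty: a 1.9-fold lower number from compound 1 to compound 3 (0.27 log units; within the scatter). The estimate for compound 3 in this assay is 12000 nM, expected to fall between 4000 nM and 40000 nM.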

Compound 3, concentration for 50% growth inhibition: 36200 nM
Compound 3: middle estimate off by 3.0-fold (0.48 log units), on the low side, and the stated range covers the measured number.
By their numbers in this assay, from the lowest: compound 2; then compounds 1 and 3 (each within the scatter of the next).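

In this assay the exchange of methyl for phenyl on the amine nitrogen of the ring gives a 1.6-fold higher number from compound 1 to compound 3 (0.21 log units; within the scatter) and so leaves compound 3 within the scatter of compound 1, even though the entering group adds a six-membered aromatic ring of carbon only. The step of a 4.2-fold higher number from compound 2 to compound 3 (0.62 log units; beyond the scatter) keeps compound 2 apart from compound 3 as well as from compound 1, so among the three compounds the ((4-chlorophenyl)amino)amino group is the only substituent on the carbonyl carbon that goes with a number set apart from the others. No supporting data bear on this result, and the numbers alone give no explanation for it.

Open, from the compounds shown here alone, is whether a hydrogen, a benzyl group or a 4-chlorophenyl group on that ring nitrogen would give a number beyond the scatter of compound 1. Also open, going by these compounds, is whether the lower number of compound 2 goes with its chlorine atom or with the ((4-chlorophenyl)amino)amino group as a whole, which an unsubstituted (phenylamino)amino group on the same carbonyl carbon would help to separate.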